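The source may hold more compounds than are shown below. What is called first, only, known or untested is meant among the compounds shown, and "the series" means these compounds.

The measured compounds:
compound 1 `N#C/N=C1\N(CCCCCCCOc2ccc(Cl)cc2)C(=O)CN1c1ccncc1` — 815 nM
compound 2 `CCC1C(=O)N(CCCCCCOc2ccc(Cl)cc2)/C(=N\C#N)N1c1ccncc1` — 6910 nM
compound 3 `CCC1C(=O)N(CCCCCCCOc2ccc(Cl)cc2)/C(=N\C#N)N1c1ccncc1` — 4540 nM

All three were tested in a functional assay on MCF7 cells (Homo sapiens) for cytotoxicity; on this read-out lower numbers stand for stronger inhibition and higher numbers for weaker inhibition. Compound 3 gives the second highest of the three numbers. Its nearest neighbour is compound 2: the difference a 1.5-fold lower number from compound 2 to compound 3 (0.18 log units; within the scatter) is within the scatter, so the two cannot be told apart. The furthest is compound 1: the step of a 5.6-fold higher number from compound 1 to compound 3 (0.75 log units; beyond the scatter) lies beyond the scatter and goes with ethyl in place of hydrogen on a saturated ring carbon of the shared core.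

Compound 4 `N#C/N=C1\N(CCCCCCCOc2ccc(Cl)cc2)C(=O)C(c2ccccc2)N1c1ccncc1` carries the change (phenyl in place of ethyl on a saturated ring carbon). Going by the values given here, only one measured step touches this place, namely a 5.6-fold higher number from compound 1 to compound 3 (0.75 log units; beyond the scatter), where a group first appeared on that carbon. The step from compound 2 to compound 3 concerns the chain, a different position, and adds nothing here. With a still larger group on the same carbon, a further rise and a number close to that of compound 3 are both possible, so a small further increase is expected, a 1.5-fold higher number from compound 3 to compound 4 (0.19 log units; within the scatter). The estimate for compound 4 in this assay is therefore 7000 nM, with a range from 2500 nM to 20000 nM.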

Compound 4, half-maximal inhibitory concentration: 1170 nM
Compound 4: the middle estimate sits 6.0-fold (0.78 log units) above what was measured; measured number outside the range, below it.
By their numbers in this assay, from the lowest: compounds 1 and 4 (each within the scatter of the next); then compounds 3 and 2 (each within the scatter of the next).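

In this assay, going by these compounds alone, phenyl in place of ethyl on this saturated ring carbon gives a 3.9-fold lower number from compound 3 to compound 4 (0.59 log units; beyond the scatter) and so reverses much of the rise that came with ethyl, which the earlier compounds could not show. Set against hydrogen on the same carbon, phenyl gives a 1.4-fold higher number from compound 1 to compound 4 (0.16 log units; within the scatter) and cannot be told apart from it, so filling this carbon does not by itself raise the number, and the number does not follow the count of heavy atoms in the group: ethyl, the smaller of the two groups, is the one that goes with the higher number. No measurement shown here accounts for why phenyl and ethyl part ways at this carbon.

The compounds shown leave open whether a cyclohexyl or a benzyl group on this carbon would stay with phenyl or with ethyl, and so whether the aromatic ring itself goes with the lower number. They also leave open whether phenyl at this place would give the same picture on the shorter chain of compound 2.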